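This account rests on a few compounds, and the source may have more. Where it says the series, first, only, none or still open, it means among the compounds named here.

Of the compounds shown here, three that share one core have been tested so far in an ADME assay on BJ cells (Homo sapiens) for cytotoxicity, with a stated time of 72 h; on this read-out lower numbers stand for an effect already at smaller amounts and higher numbers for an effect only at larger amounts of compound. Among the measured compounds shown here, compound 1 (`Cc1cc(NC(=O)Nc2ccc(C(C)(C)C)cc2)c2ccccc2n1`) gives 20000 nM as its result, the only true number of the three. Compound 2 (`Cc1cc(NC(=O)Nc2ccccc2N)c2ccccc2n1`) gives > 25000 nM as its result, which is a limit of the assay and not a number. Compound 3 (`Cc1cc(NC(=O)Nc2cc(F)cc(F)c2)c2ccccc2n1`) gives > 25000 nM as its result, again a limit. The small set is thus shaped by the limit of > 25000 nM in this assay, at which 2 of the 3 values shown sit, and compound 1 is the only starting point with a real number.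

Compound 4 (`Cc1cc(NC(=O)Nc2ccc(C(F)(F)F)cc2)c2ccccc2n1`) keeps the core of compound 1 and alters a single group: trifluoromethyl in place of tert-butyl on an aromatic carbon, para to a large group (trifluoromethyl in place of tert-butyl on an aromatic carbon). For the measured compounds named here, no measured pair shows what this swap does in this assay, so the expectation rests on compound 1 and its value of 20000 nM as the nearest reference. The estimated move is a 1.1-fold higher number from compound 1 to compound 4 (0.04 log units; within the scatter) in size, which is expected to stay within the usual scatter, with no firm direction. A result given only as a limit would be no surprise. For compound 4 the expected value is 22000 nM with an estimated range from 12000 nM to 40000 nM once it is measured.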

Compound 4, half-maximal effective concentration: > 25000 nM
Compound 4 ended at the assay's limit; the forecaster's own chance of this, stated with the estimate: 45%; middle value at least 1.1-fold (0.05 log units) from the limit.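

Among the compounds shown here, this pair gives the first step between two compounds that differ in one place in this assay: with trifluoromethyl in place of tert-butyl on an aromatic carbon, para to a large group, the result is an at least 1.2-fold higher number from compound 1 to compound 4 (0.09 log units; that floor lies within the scatter). The step is only a floor, so it shows the direction of the difference but not its true size, and the floor itself does not go beyond the usual scatter. Its size cannot be narrowed any further, and compound 1 remains the only compound in the set with a true number, because the other results are limits and not numbers: the limit of > 25000 nM in this assay, at which 3 of the 4 values shown sit.

On these data alone, it remains open whether the real number of compound 1 depends on tert-butyl specifically or whether other groups at this same place would also give a real number. A methoxy group, a carboxylic acid or a longer alkyl chain in that position would test this. Each would be compared directly with compound 1, as only one place would differ.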